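The source may report more compounds than this note shows. Statements on the series, on what has been measured and on what is new or still open speak of the compounds shown alone.

Going by the values given here, in a functional assay on CCRF-CEM cells (Homo sapiens) for antiproliferative activity (on this read-out higher numbers stand for weaker inhibition of growth and lower numbers for stronger inhibition of growth), compound 1 `COCCCCCCCCCCC/C=C1\CC(CO)(COC(=O)C(C)(C)C)OC1=O` gives 0.701 ug/mL and compound 2 `CC(C)(C)C(=O)OCC1(CO)C/C(=C\CCCCCCCCCCCO)C(=O)O1` gives 0.65 ug/mL and so stands level with it, within the scatter; these are the only two numbers so far. Compound 3 `CC(=O)OCCCCCCCCCCCCCCC/C=C1\CC(CO)(COC(=O)C(C)(C)C)OC1=O` is still unmeasured and differs from compound 2 by a single change. That change is 4-acetoxybutyl in place of hydroxy on a saturated chain carbon, ten or more bonds along the chain from a double-bonded chain carbon. The measured step of a 1.1-fold lower number from compound 1 to compound 2 (0.03 log units; within the scatter) is the only one that bears on this. It puts hydrogen in place of methyl on an oxygen on a saturated carbon, a much smaller edit, so it offers no direction. No shift beyond the scatter is therefore expected in this assay and the estimated move is a 1.2-fold higher number from compound 2 to compound 3 (0.09 log units; within the scatter) with considerable uncertainty. For compound 3 the expected value is 0.8 ug/mL with an estimated range from 0.25 ug/mL to 2.5 ug/mL around it.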

Compound 3, concentration for 50% growth inhibition: 7.55 ug/mL
Compound 3: middle estimate off by 9.4-fold (0.97 log units), on the low side; the whole stated range lies below it.
By their numbers in this assay, from the lowest: compounds 2 and 1 (each within the scatter of the next); then compound 3.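

In this assay, the far end of the chain proved sensitive to a larger edit, although hydroxy and methoxy there gave numbers level with each other. Placing 4-acetoxybutyl there instead of hydroxy weakens growth inhibition (a 12-fold higher number from compound 2 to compound 3 (1.07 log units; beyond the scatter)), and placing it there instead of methoxy does much the same (an 11-fold higher number from compound 1 to compound 3 (1.03 log units; beyond the scatter)). No measurement at hand explains this shift.

The edit both lengthens the chain and ends it in an acetoxy group, so the compounds shown cannot tell which of these matters: a simple hydroxy on the longer chain, or an acetoxy on the shorter one, would separate the two. From the compounds shown here alone, it also remains open how an amine or a carboxylic acid at the chain end would behave.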